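A few compounds are considered here, and "the series" means these few. Any claim that something is new, unique, unknown or untested is made for them only; others in the source may bear on it.

In an ADME assay on Huh-7 cells (Homo sapiens) for cytotoxicity, read by MTT assay, with a stated time of 72 h (on this read-out lower numbers stand for higher toxicity in this test and higher numbers for lower toxicity in this test), compound 2 `COc1cc(OC)c2c(=O)cc(-c3ccc(OCc4cn(-c5ccc(F)c(Cl)c5)nn4)c(OC)c3)oc2c1` gives > 100 ug/mL, which is a limit of the assay rather than a measured number. Compound 1 `COc1cc(OC)c2c(=O)cc(-c3ccc(OCc4cn(-c5ccccc5Cl)nn4)c(OCc4cn(-c5ccccc5Cl)nn4)c3)oc2c1` gives > 100 ug/mL in this assay, again a limit. Because both readings sit at the limit of > 100 ug/mL in this assay, at which 2 of the 2 values shown sit, compound 2 stands where every measured compound stands. Compound 3 `COc1cc(OC)c2c(=O)cc(-c3ccc(OCc4cn(-c5ccccc5Cl)nn4)c(OC)c3)oc2c1` differs from compound 2 by 2-chlorophenyl in place of 3-chloro-4-fluorophenyl on an aromatic nitrogen. The expected step is a step that the limit leaves unreadable from compound 2 to compound 3, nothing beyond the scatter. Compound 3 is therefore expected to give about 120 ug/mL, somewhere between 60 ug/mL and 250 ug/mL.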

Compound 3, half-maximal cytotoxic concentration: > 100 ug/mL
Compound 3 gave a limit, no number (the forecaster's own chance of this, stated with the estimate: 80%); the middle value is on the limit's open side.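

Among the compounds shown here, compound 1, compound 2 and compound 3 all stop at a limit of the assay, so no step between them can be read: the limit of > 100 ug/mL in this assay, at which 3 of the 3 values shown sit.
The compounds shown leave open whether the groups that differ change anything in this assay at higher concentrations.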